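The compounds below may be only part of what the source reports. "The series", "measured", "known", "first", "only" and "open" are said of these compounds alone.

Compound 1 `CCCCCSc1nc(NCc2ccc([Se]C)cc2)c2ccccc2n1` and compound 2 `CSc1nc(NCc2ccc([Se]C)cc2)c2ccccc2n1` share one core, and compound 3 `CCCCC[Se]c1nc(N)c2cccnc2n1` and the not yet measured compound 4 `C[Se]c1nc(N)c2cccnc2n1` share another; the difference between the two cores is not broken down here. In a functional assay on HT-29 cells (Homo sapiens) for cytotoxicity, read by MTT assay, with a stated time of 72 h (a higher number here means a weaker inhibitor of growth, a lower number a stronger inhibitor of growth), compound 1 gives > 100000 nM, which is a limit of the assay and not a number. In this assay compound 2 gives > 100000 nM, again a limit. In this assay, among the compounds with values here, compound 3 gives 20000 nM, the only numerical value among the three. Compound 1 and compound 2 both sit at the limit of > 100000 nM in this assay, at which 2 of the 3 values shown sit. The change from compound 1 to compound 2, (hydrogen in place of butyl on a saturated chain carbon bound to a sulfur), therefore produced a step that the two limits leave unreadable from compound 1 to compound 2. The change planned from compound 3 to compound 4, (hydrogen in place of butyl on a saturated chain carbon bound to a selenium atom), is the same kind of change, differing only in what the chain carbon is bound to: a sulfur in the first pair, a selenium atom in the second. Within the data shown here, compound 4 is expected to sit around 30000 nM, within 8000 nM to 100000 nM, meaning an expected step of a 1.5-fold higher number from compound 3 to compound 4 (0.18 log units; within the scatter), since the one measured example of this change gives no readable size and compound 3 at 20000 nM is the only anchor.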

Compound 4, concentration for total growth inhibition: 77300 nM
Compound 4: the middle estimate sits 2.6-fold (0.41 log units) below what was measured, and the stated range covers the measured number.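

In this assay the change of hydrogen in place of butyl on a saturated chain carbon bound to a selenium atom gives a 3.9-fold higher number from compound 3 to compound 4 (0.59 log units; beyond the scatter) on this core, so here the shorter chain goes with weaker inhibition of growth. On the other core the same kind of change cannot be read, because compound 1 and compound 2 both sit at a limit of the assay and not at a number: the limit of > 100000 nM in this assay, at which 2 of the 4 values shown sit. Within the data shown here, the one readable step therefore gives a size on a single core and does not show that the change carries from one core to the other, and the two pairs also differ in having a sulfur or a selenium atom bound to the chain carbon.

The compounds shown leave open how a propyl or a hexyl chain would sit on the core of compound 3. They also leave open whether an amine or a carboxylic acid at the end of the chain would move the number on either core.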